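Shortening the Carbonate Ester from Isopropyl to Ethyl

The source may hold more compounds than are shown below. What is called first, only, known or untested is meant among the compounds shown, and "the series" means these compounds.

Three carbonate esters of a shared core have been followed in an ADME assay for pharmacokinetics, read by HPLC, in phosphate buffer, at 37 degrees C, at pH 6.0; a higher number here means that the compound lasts longer, a lower number that the compound disappears faster. Compound 1 `CC(C)CCOC(=O)OCC(CO)CCn1cnc2cnc(N)nc21` gives 1560 h and compound 2 `CC(C)COC(=O)OCC(CO)CCn1cnc2cnc(N)nc21` gives 2090 h. For compound 3 `CC(C)OC(=O)OCC(CO)CCn1cnc2cnc(N)nc21` this assay reports only a limit, > 4800 h. Compound 3 thus sits at the limit of > 4800 h in this assay, at which 1 of the 3 values shown sits, with no fixed number of its own.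

Compound 4 `CCOC(=O)OCC(CO)CCn1cnc2cnc(N)nc21` differs from compound 3 by hydrogen in place of methyl on a saturated chain carbon bound to an oxygen next to a carbonyl group and a saturated chain carbon. The step of a 1.3-fold higher number from compound 1 to compound 2 (0.13 log units; within the scatter) shows that trimming the ester chain by itself did little. Within the data shown here, the steps that bear on the present change are an at least 3.0-fold higher number from compound 1 to compound 3 (0.48 log units; beyond the scatter) and an at least 2.2-fold higher number from compound 2 to compound 3 (0.36 log units; beyond the scatter), both pointing toward the isopropyl ester. Moving from isopropyl to ethyl goes the other way, so a modest fall is expected, an at least 2.0-fold lower number from compound 3 to compound 4 (0.30 log units; that floor lies within the scatter), and no rise beyond the limit. Compound 4 is expected at 2400 h, with a range from 1100 h to 5500 h.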

Compound 4, half-life: 2690 h
Compound 4: middle estimate off by 1.1-fold (0.05 log units), on the low side; low and high end bracket the measured number.
By their numbers in this assay, from the lowest: compounds 1, 2 and 4 (each within the scatter of the next). At a limit, above all of these: compound 3.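

Taking isopropyl to ethyl gives an at least 1.7-fold lower number from compound 3 to compound 4 (0.25 log units; that floor lies within the scatter), so this floor alone does not establish a real loss, and the full size of the step cannot be read from a limit: the limit of > 4800 h in this assay, at which 1 of the 4 values shown sits. In this assay the ethyl ester does not separate from the two longer esters, with a 1.3-fold higher number from compound 2 to compound 4 (0.11 log units; within the scatter) and a 1.7-fold higher number from compound 1 to compound 4 (0.24 log units; within the scatter). Among these compounds, compounds 1, 2 and 4 thus form one group within the scatter, whereas the earlier compounds alone had left the ethyl ester's place unknown.

As far as these compounds go, whether compound 4 truly differs from compound 3 by more than the scatter remains open while compound 3 has no fixed number. Also open, from the compounds shown here alone, is how a methyl or tert-butyl group on this oxygen, or an amine in the chain, would fare.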